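This account rests on a few compounds, and the source may have more. Where it says the series, first, only, none or still open, it means among the compounds named here.

Of the compounds shown here, three from this series have so far been measured in a functional assay on T47D cells (Homo sapiens) for activation; on this read-out lower numbers stand for an effect already at smaller amounts and higher numbers for an effect only at larger amounts of compound. Compound 1 `COc1ccc2c(c1)OC(N)=C(C#N)C2c1ccccc1` gives 360000000 nM in this assay. Compound 2 `COc1cc(C2C(C#N)=C(N)Oc3cc(Br)ccc32)cc(Br)c1OC` gives 140000000 nM, and compound 3 `CCNc1ccc2c(c1)OC(N)=C(C#N)C2c1cccc(OC)c1` gives 110000000 nM. Among these three numbers, compound 1 stands highest: the gap to compound 2 and the larger gap to compound 3 both lie beyond the usual scatter of repeated measurements, so compound 1 needs the largest amount of all three for a half-maximal effect.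

Compound 4 `COc1ccc2c(c1)OC(N)=C(C#N)C2c1cccnc1` has not yet been measured. It differs from compound 1 in a single place: pyridin-3-yl in place of phenyl on a saturated ring carbon. Among the measured compounds shown here, no pair of the measured compounds differs by just one change, so there is no step in this assay that directly shows what such a swap does. In the absence of such a guide, the step from compound 1 to compound 4 is expected to stay within the usual scatter, with no clear direction. The expected step is a 1.2-fold lower number from compound 1 to compound 4 (0.08 log units; within the scatter). Compound 4 is therefore estimated at 300000000 nM in this assay, with a range from 100000000 nM to 900000000 nM.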

Compound 4, half-maximal effective concentration: 170000000 nM
Estimate against measurement, compound 4: 1.8-fold (0.25 log units) above; the measured number falls inside the stated range.
By their numbers in this assay, from the lowest: compounds 3, 2 and 4 (each within the scatter of the next); then compound 1.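

Among the compounds shown here, this is the first comparison that changes only one place: pyridin-3-yl in place of phenyl on the saturated ring carbon gives a 2.1-fold lower number from compound 1 to compound 4 (0.33 log units; beyond the scatter) in this assay. The step is modest but beyond the scatter, so the assay does register this exchange of one ring carbon for nitrogen, with the ring still six-membered and aromatic. Nothing in the available data accounts for the step.

Going by these compounds, it remains open whether the placement of the ring nitrogen matters, which pyridin-2-yl or pyridin-4-yl at this carbon could test, and whether a non-aromatic ring such as cyclohexyl would be tolerated. This single step also cannot show whether the same exchange would act similarly on the differently substituted cores of compound 2 and compound 3.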